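Swapping a ring-bearing arm for a sulfur chain on the shared core

This account rests on a few compounds, and the source may have more. Where it says the series, first, only, none or still open, it means among the compounds named here.

Of the compounds shown here, three built on one shared core have been tested in an assay for inhibition of Fatty-acid amide hydrolase 1 (Rattus norvegicus), using a Dixon plot, with a stated time of 3 h; on this read-out lower numbers stand for stronger inhibition and higher numbers for weaker inhibition. Compound 1 `O=C(CCCCCCc1ccccc1)c1ncc(-c2ccc(CCl)cn2)o1` gives 20.1 nM, the highest number of the three. Compound 2 `N#C/C=C/c1ccc(-c2cnc(C(=O)CCCCCCc3ccccc3)o2)nc1` gives 2.7 nM, and compound 3 `CSC(=O)CCCCc1cnc(C(=O)CCCCCCc2ccccc2)o1` gives 1.4 nM. Both changes away from compound 1 therefore moved toward stronger inhibition: a 7.4-fold lower number from compound 1 to compound 2 (0.87 log units; beyond the scatter), and a 14-fold lower number from compound 1 to compound 3 (1.16 log units; beyond the scatter).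

Compound 4 `CSCCCCCc1cnc(C(=O)CCCCCCc2ccccc2)o1` is the next step from compound 1. The change is a group of 7 heavy atoms (6 carbon, 1 sulfur; no ring) in place of a group of 8 heavy atoms (6 carbon, 1 nitrogen, 1 chlorine; one six-membered aromatic ring with 1 hetero atom), on an aromatic carbon: the group that leaves carries the six-membered aromatic ring with its chloromethyl arm, and the 5-(methylsulfanyl)pentyl group that enters is an open chain ending in sulfur. Among the measured compounds shown here, the closest measured step is the one from compound 1 to compound 3, where an open chain of similar length containing sulfur also replaced the same ring-bearing group and gave the large gain seen in this assay. The step from compound 1 to compound 2 is less directly comparable, since the ring stays there, but it points the same way.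

On that basis compound 4 is expected to give a lower number than compound 1, by a 6.7-fold lower number from compound 1 to compound 4 (0.83 log units; beyond the scatter). The estimated value for compound 4 is 3 nM, with a range from 1 nM to 10 nM.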

Compound 4, inhibition constant: 6.4 nM
For compound 4 the middle estimate is 2.1-fold (0.33 log units) below the measured one, within the range that was stated.
By their numbers in this assay, from the lowest: compounds 3 and 2 (each within the scatter of the next); then compound 4; then compound 1.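

In this assay the step of a 3.1-fold lower number from compound 1 to compound 4 (0.50 log units; beyond the scatter) shows that this aromatic carbon of the shared core does not need the six-membered aromatic ring to give a lower number than compound 1 does: the open 5-(methylsulfanyl)pentyl chain does so with no ring at all. The earlier compounds shown here could not separate the chain from the carbonyl within it, and the step of a 4.6-fold higher number from compound 3 to compound 4 (0.66 log units; beyond the scatter) now does, with (methylsulfanyl)methyl in place of (methylsulfanyl)carbonyl at that one spot on the chain. So the chain alone accounts for part of what compound 3 gained over compound 1, and the carbonyl makes a further difference beyond the scatter; nothing shown here gives a measured reason for either effect.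

Still open, as far as these compounds go, is whether the sulfur itself matters, since every open chain here carries it, and a plain hexyl chain or a methoxy-ended chain would test that directly. It is also unknown how a carboxylic acid, a methyl ester or an amide at the end of the chain would compare with the (methylsulfanyl)carbonyl group, or how a longer chain would behave at this position.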